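The source may hold more compounds than are shown below. What is called first, only, known or untested is meant among the compounds shown, and "the series" means these compounds.

Compound 2 `CC(C)[C@H](NC(=O)COc1cccc2ccccc12)C(=O)N[C@@H](CC(=O)O)C(=O)COc1ccccc1C(F)(F)F` is one of three compounds that share a core and differ only in the aryl group on an oxygen on a saturated carbon. In a functional assay with Homo sapiens as the target (a higher number here means a weaker inhibitor, a lower number a stronger inhibitor), compound 2 gives 17300 nM. Compound 1 `CC(C)[C@H](NC(=O)COc1cccc2ccccc12)C(=O)N[C@@H](CC(=O)O)C(=O)COc1ccc2ccccc2c1` gives 15900 nM in this assay. Compound 3 `CC(C)[C@H](NC(=O)COc1cccc2ccccc12)C(=O)N[C@@H](CC(=O)O)C(=O)COc1ccc(C#N)cc1` gives 26700 nM in this assay. The three numbers sit close together: a 1.1-fold higher number from compound 1 to compound 2 (0.04 log units; within the scatter), a 1.5-fold higher number from compound 2 to compound 3 (0.19 log units; within the scatter) and a 1.7-fold higher number from compound 1 to compound 3 (0.23 log units; within the scatter), so compound 2 stands within the scatter of both of its companions.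

Compound 4 `CC(C)[C@H](NC(=O)COc1cccc2ccccc12)C(=O)N[C@@H](CC(=O)O)C(=O)COc1c(F)cccc1F` has not yet been measured. It differs from compound 2 by 2,6-difluorophenyl in place of 2-(trifluoromethyl)phenyl on an oxygen on a saturated carbon. The two steps that touch compound 2, a 1.1-fold higher number from compound 1 to compound 2 (0.04 log units; within the scatter) and a 1.5-fold higher number from compound 2 to compound 3 (0.19 log units; within the scatter), exchanged the aryl group at this same position and left the number within the scatter, as did a 1.7-fold higher number from compound 1 to compound 3 (0.23 log units; within the scatter). No step beyond the scatter is therefore expected for compound 4, and the expected step is a 1.0-fold higher number from compound 2 to compound 4 (0.02 log units; within the scatter). Compound 4 is estimated at 18000 nM in this assay, with a range from 8000 nM to 40000 nM.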

Compound 4, half-maximal inhibitory concentration: > 100000 nM
Compound 4: only a limit was reported; the forecaster's own chance of this, stated with the estimate: 10%; middle value at least 5.5-fold (0.74 log units) from the limit.
By their numbers in this assay, from the lowest: compounds 1, 2 and 3 (each within the scatter of the next). At a limit, above all of these: compound 4.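

At this position the aryl group turns out not to be freely exchangeable: the earlier exchanges all stayed within the scatter, whereas 2,6-difluorophenyl brings an at least 5.7-fold higher number from compound 2 to compound 4 (0.76 log units; beyond the scatter), an at least 3.7-fold higher number from compound 3 to compound 4 (0.57 log units; beyond the scatter) and an at least 6.2-fold higher number from compound 1 to compound 4 (0.79 log units; beyond the scatter). Compound 4 is reported only as a limit of the assay, and the full size of these steps cannot be read from it: the limit of > 100000 nM in this assay, at which 1 of the 4 values shown sits. The leaving 2-(trifluoromethyl)phenyl and the entering 2,6-difluorophenyl each count one six-membered aromatic ring of carbon only and no hydrogen-bond donors or acceptors, so the position responds to a change that these counts do not register.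

The compounds shown leave open whether a 2-fluorophenyl group would stand with compound 2 or with compound 4, and how an amine or a carboxylic acid on the phenyl ring would fare. Nothing shown tells what lies behind the step.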